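This account rests on a few compounds, and the source may have more. Where it says the series, first, only, none or still open, it means among the compounds named here.

Measured so far in a functional assay on MCF7 cells (Homo sapiens) for inhibition, read by sulforhodamine B assay; on this read-out lower numbers stand for stronger inhibition and higher numbers for weaker inhibition

- Compound 1 `CCCc1ccc(NC2=CC(=O)c3nc4n(c3C2=O)[C@H]2OC[C@@H](O)[C@H]2OC4)cc1` gives 4660 nM
- Compound 2 `O=C1C(Nc2ccccc2)=CC(=O)c2c1nc1n2[C@H]2OC[C@@H](O)[C@H]2OC1` gives > 4000 nM (a limit)
- Compound 3 `O=C1C=C(N2CCC2)C(=O)c2c1nc1n2[C@H]2OC[C@@H](O)[C@H]2OC1` gives > 16000 nM (a limit)

Only compound 1 has a true number in this series. Compound 2 gives only a limit (> 4000 nM), so no number fixes its place among the three. Compound 3 is also reported only as a limit (> 16000 nM).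

The next compound to be measured is compound 4 `Cc1ccc(NC2=CC(=O)c3c(nc4n3[C@H]3OC[C@@H](O)[C@H]3OC4)C2=O)cc1C`, and it departs from compound 2 at a single place. The change is 3,4-dimethylphenyl in place of phenyl on an amine nitrogen and amounts to 3,4-dimethylphenyl in place of phenyl on an amine nitrogen. Among the compounds with values here, no measured pair shows this change, so the expectation rests on one nearby example. Compound 1 (4660 nM) also carries a substituted phenyl on the amine nitrogen, and it is the closest guide to a number for compound 4. Reckoned from a limit, the expected step (a step that the limit leaves unreadable from compound 2 to compound 4) is no larger than the usual scatter and has no clear direction. A report of only a limit would also be no surprise. In this assay the estimated value for compound 4 is 5000 nM with an expected range from 2000 nM to 12000 nM.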

Compound 4, half-maximal inhibitory concentration: 4950 nM
Compound 4: the middle estimate sits 1.0-fold (0.00 log units) above what was measured, within the range that was stated.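

Within the data shown here, compound 2 is reported in this assay only as a limit, > 4000 nM, so no step from compound 2 to compound 4 can be read. The compounds shown leave open whether 3,4-dimethylphenyl in place of phenyl on the amine nitrogen changes inhibition in this assay at all, and in which direction.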